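Thiazolo-fused series: cytotoxicity notes, compound 3 pending

A few compounds are considered here, and "the series" means these few. Any claim that something is new, unique, unknown or untested is made for them only; others in the source may bear on it.

Measured so far:
compound 1 `Cc1cc(CO)c2n1[C@@H](c1ccccc1)SC2` — 110000 nM
compound 2 `Cc1c(CO)c(CO)c2n1[C@@H](c1ccccc1)SC2` — 12200 nM

In a functional assay on MCF7 cells (Homo sapiens) for cytotoxicity, read by MTT assay, with a stated time of 24 h (a lower number here means a stronger inhibitor, a higher number a weaker inhibitor), compound 1 gives 110000 nM and compound 2 gives 12200 nM. Going by the values given here, the only step is a 9.0-fold lower number from compound 1 to compound 2 (0.96 log units; beyond the scatter). On these two numbers compound 2 has the lower value, set apart from compound 1 by a step beyond the scatter.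

Compound 3 `OCc1c(CO)c(-c2ccccc2)n2c1CS[C@@H]2c1ccccc1` has not been measured. It differs from compound 2 in one place: phenyl in place of methyl on an aromatic carbon. Among the compounds with values here, no measured step bears on this change; the one known step concerns hydroxymethyl in place of hydrogen and says nothing about phenyl in place of methyl. The expectation therefore rests on compound 2 alone, with a wide range and no direction preferred. For compound 3 in this assay the estimate is 9000 nM (range 2500 nM to 35000 nM), which is expected to mean a step of a 1.4-fold lower number from compound 2 to compound 3 (0.13 log units; within the scatter), not judged beyond the scatter.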

Compound 3, half-maximal inhibitory concentration: 92600 nM
Compound 3: the middle estimate sits 10-fold (1.01 log units) below what was measured; the whole stated range lies below it.
By their numbers in this assay, from the lowest: compound 2; then compounds 3 and 1 (each within the scatter of the next).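

Going by these compounds alone, the aromatic carbon next to the ring nitrogen had carried only methyl, and the earlier compounds gave no reading of a change there. In this assay, phenyl in place of methyl gives a 7.6-fold higher number from compound 2 to compound 3 (0.88 log units; beyond the scatter), so this position is sensitive to the group it carries, and the change moves the number toward the weaker side. This is a single pair, and no supporting data bear on the reason for the step.

On these data alone, whether the higher number is specific to phenyl or would follow from other replacements of methyl stays open; an ethyl group, an amine or a phenyl ring bearing a carboxylic acid at this carbon would help separate these. Also open, as far as these compounds go, is whether a 9.0-fold lower number from compound 1 to compound 2 (0.96 log units; beyond the scatter), seen with hydroxymethyl in place of hydrogen, would recur with phenyl at this position.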